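Compound 2 to compound 4: removing the ring substituents

The compounds below may be only part of what the source reports. "The series", "measured", "known", "first", "only" and "open" are said of these compounds alone.

Measured in a functional assay, read by spectrophotometry, with a stated time of 5 min; on this read-out lower numbers stand for stronger inhibition and higher numbers for weaker inhibition:
- compound 1 `CCOc1cc(C=C(C(=O)/C=C/c2ccc(O)c(OC)c2)C(=O)/C=C/c2ccc(O)c(OC)c2)ccc1O`: 123000000 nM
- compound 2 `CCOc1cc(/C=C/C(=O)C(=Cc2ccc(O)c(OC)c2)C(=O)/C=C/c2ccc(O)c(OCC)c2)ccc1O`: 60500000 nM
- compound 3 `CCOc1cc(/C=C/C(=O)C(=Cc2ccc(OC)c(OC)c2)C(=O)/C=C/c2ccc(O)c(OCC)c2)ccc1O`: 53200000 nM

Compound 2 stands at 60500000 nM, level within the scatter with compound 3, while compound 1 carries the higher number of the two at 123000000 nM.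

Compound 4 `CCOc1cc(/C=C/C(=O)C(=Cc2ccccc2)C(=O)/C=C/c2ccc(O)c(OCC)c2)ccc1O` has not yet been measured. Relative to compound 2 it has phenyl in place of 4-hydroxy-3-methoxyphenyl on a double-bonded chain carbon bound to a double-bonded chain carbon.

Among the compounds with values here, one measured step bears on this group: a 1.1-fold lower number from compound 2 to compound 3 (0.06 log units; within the scatter), with methyl in place of hydrogen on an oxygen on an aromatic ring. Within the data shown here, that step is small, but it does not remove the group's oxygens, and no measured compound lacks them, so the evidence is limited. No step beyond the scatter is expected in this assay, in either direction, though the uncertainty is wide.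

The expected change is a 1.0-fold lower number from compound 2 to compound 4 (0.00 log units; within the scatter).

For compound 4 the estimate is 60000000 nM, with an expected range of 20000000 nM to 150000000 nM.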

Compound 4, half-maximal inhibitory concentration: 91400000 nM
Compound 4: the middle estimate sits 1.5-fold (0.18 log units) below what was measured, and the stated range covers the measured number.
By their numbers in this assay, from the lowest: compounds 3, 2, 4 and 1 (each within the scatter of the next, the first and the last beyond it).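

In this assay the loss of the ring substituents gives a 1.5-fold higher number from compound 2 to compound 4 (0.18 log units; within the scatter) and, from the methylated analogue, a 1.7-fold higher number from compound 3 to compound 4 (0.24 log units; within the scatter) with phenyl in place of 3,4-dimethoxyphenyl. Both steps lie within the scatter. The earlier step only placed a methyl on an oxygen, whereas these two take away the ring oxygens altogether, and for 4-hydroxy-3-methoxyphenyl also the hydrogen-bond donor. On a double-bonded chain carbon bound to a double-bonded chain carbon, the bare phenyl therefore stays level with both substituted rings on this read-out. Nothing available explains this result.

As far as these compounds go, whether an amine or a carboxylic acid on this ring would give a step beyond the scatter remains open. So does the response to a halogen such as chlorine at this position.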